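Dimethylamino for acetyl on the pyridine-linked phenyl ring

A few compounds are considered here, and "the series" means these few. Any claim that something is new, unique, unknown or untested is made for them only; others in the source may bear on it.

Compound 1 `COc1cc(C)cc(-c2c(-c3ccnc(-c4ccc(C(C)=O)cc4)c3)cnn2CC#N)c1` and compound 2 `COc1cc(C)cc(-c2nn(CC#N)cc2-c2ccc(-c3cccc(C(C)=O)c3)nc2)c1` share one core. In a functional assay on A549 cells (Homo sapiens) for cytotoxicity, read by sulforhodamine B assay, with a stated time of 48 h, tested at 100 nM (on this read-out lower numbers stand for a stronger effect and higher numbers for a weaker effect at the one concentration tested), compound 1 gives 83%, and compound 2 gives 91%; the two numbers lie within the usual scatter of each other, so neither stands apart. Compound 3 `COc1cc(C)cc(-c2c(-c3ccnc(-c4ccc(N(C)C)cc4)c3)cnn2CC#N)c1` has not been measured. It differs from compound 1 by dimethylamino in place of acetyl on an aromatic carbon. With no measured step of this kind in hand, the expected step of a number 2 percentage points higher from compound 1 to compound 3 (within the scatter) is none beyond the scatter. Compound 3 is therefore estimated at 85%, with a range from 65% to 100%.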

Compound 3, a percentage reported as activity, at one concentration (the size of the read-out at that concentration, not a potency): 10%
Compound 3: middle estimate off by 75 percentage points, on the high side, outside the stated range (below it).
By their numbers in this assay, from the lowest: compound 3; then compounds 1 and 2 (each within the scatter of the next).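

In this assay, dimethylamino in place of acetyl gives a number 73 percentage points lower from compound 1 to compound 3 (beyond the scatter), so the group on this aromatic carbon, para to a large group, strongly affects the read-out. The two groups have the same heavy-atom, donor and acceptor counts, so these counts do not separate compound 1 from compound 3. No available evidence explains the step.

The compounds shown leave open whether a simple amino group or a morpholine ring would match dimethylamino here. They also leave open whether methoxy at this position would do so.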